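From 2-methylphenyl to 4-fluorophenyl: repeating one swap

The source may hold more compounds than are shown below. What is called first, only, known or untested is meant among the compounds shown, and "the series" means these compounds.

Measured in a functional assay on A549 cells (Homo sapiens) for antiproliferative activity, read by MTT assay, with a stated time of 24 h; a higher number here means a weaker inhibitor, a lower number a stronger inhibitor:
Compound 1 `Cc1ccccc1NNC(=O)c1ccc(NS(=O)(=O)c2cnc(O)nc2O)cc1` gives 14500 nM
Compound 2 `O=C(NNc1ccc(F)cc1)c1ccc(NS(=O)(=O)c2cnc(O)nc2O)cc1` gives > 20000 nM
Compound 3 `Cc1ccccc1NNC(=O)c1cccc(NS(=O)(=O)c2cnc(O)nc2O)c1` gives 14200 nM

The value of compound 2 is a limit and not a number.

Compound 3 stands level with compound 1, as their values lie within the scatter of each other. Compound 4 `O=C(NNc1ccc(F)cc1)c1cccc(NS(=O)(=O)c2cnc(O)nc2O)c1` differs from compound 3 by a single swap (4-fluorophenyl in place of 2-methylphenyl on an amine nitrogen). The same swap has been measured once, on compound 1, and the result was an at least 1.3-fold higher number from compound 1 to compound 2 (0.13 log units; that floor lies within the scatter). That lone step points towards a weaker inhibitor in this assay, though the rise may be no larger than the scatter. Carrying it over gives an expected 1.6-fold higher number from compound 3 to compound 4 (0.21 log units; within the scatter). Compound 4 is estimated at 23000 nM, with an expected range from 13000 nM to 45000 nM.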

Compound 4, half-maximal inhibitory concentration: > 20000 nM
Compound 4: no number, only a limit (the forecaster's own chance of this, stated with the estimate: 65%); the middle value does not contradict the limit.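

On a second core, 4-fluorophenyl in place of 2-methylphenyl on an amine nitrogen again ends in a limit, not a number, in this assay, giving an at least 1.4-fold higher number from compound 3 to compound 4 (0.14 log units; that floor lies within the scatter). The change has now been read twice, and both steps point the same way: the same change on two cores in this assay, an at least 1.3-fold higher number (0.13 log units; that floor lies within the scatter) from compound 1 to compound 2 and an at least 1.4-fold higher number (0.14 log units; that floor lies within the scatter) from compound 3 to compound 4; the limit leaves it open whether they differ Both 4-fluorophenyl compounds stop at one ceiling: the limit of > 20000 nM in this assay, at which 2 of the 4 values shown sit.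

Going by these compounds, how far compound 2 and compound 4 lie past that limit stays open, so the true size of the change is unknown. Also open, on these data alone, is how a phenyl ring carrying a carboxylic acid would read on that amine nitrogen.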